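Amide variants on a shared cyclohexene core: methoxyamide

The source may report more compounds than this note shows. Statements on the series, on what has been measured and on what is new or still open speak of the compounds shown alone.

Measured compounds:
compound 1, `COc1ccc(NC(=O)[C@@H]2CC=C(CCC=C(C)C)C[C@H]2c2ccccc2)cc1`
compound 2, `CC(C)=CCCC1=CC[C@@H](C(=O)N(C)C)[C@H](c2ccccc2)C1`

In an assay on isolated protein for inhibition of Apoptosis regulator Bcl-2 (Homo sapiens), read by fluorescence polarization, with stated times of 5 min and 10 min (on this read-out higher numbers stand for weaker inhibition and lower numbers for stronger inhibition), compound 1 gives only a limit, > 23000 nM. In this assay compound 2 likewise gives only a limit, > 23000 nM. For the measured compounds named here, both values sit at the limit of > 23000 nM in this assay, at which 2 of the 2 values shown sit, so the single measured step, a step that the two limits leave unreadable from compound 1 to compound 2, cannot be read in size or direction. Compound 2 therefore stands at the limit of this assay, with no number of its own; nothing separates it from compound 1 on what has been measured.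

Compound 3, `CONC(=O)[C@@H]1CC=C(CCC=C(C)C)C[C@H]1c1ccccc1`, differs from compound 2 by methoxyamino in place of dimethylamino on a carbonyl carbon. No measured step in the series bears directly on this change; the one step shown, from compound 1 to compound 2, also replaces the group on the carbonyl carbon and is unreadable between two limits. With both measured values at the limit, the expectation for compound 3 is that this assay again reports a limit, and the step that the limit leaves unreadable from compound 2 to compound 3 is expected to be none beyond the scatter. Compound 3 is estimated at 40000 nM, with a range from 15000 nM to 150000 nM.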

Compound 3, inhibition constant: 2700 nM
Compound 3: middle estimate off by 15-fold (1.17 log units), on the high side; the measured number lies below the stated range.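

For the compounds shown here, compound 3 is the first compound with a number of its own in this assay, so the group on the carbonyl carbon is now seen to matter, with an at least 8.5-fold lower number from compound 2 to compound 3 (0.93 log units; beyond the scatter) for methoxyamino in place of dimethylamino. Against the aryl amide the reading is an at least 8.5-fold lower number from compound 1 to compound 3 (0.93 log units; beyond the scatter) for methoxy in place of 4-methoxyphenyl on the amide-type nitrogen. Each of these steps has a limit at one end and so gives a bound rather than a full size, and of the three amides only the methoxycarbamoyl one leaves that limit: the limit of > 23000 nM in this assay, at which 2 of the 3 values shown sit.

The change from dimethylamino to methoxyamino brings in the amide hydrogen and the methoxy oxygen together, and the compounds shown cannot say which of the two goes with the lower number. Hydroxyamino, ethoxyamino or a methyl on the nitrogen of methoxyamino would separate these readings, and they would also show how narrow the requirement on the carbonyl carbon is.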